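Iodo to Bromo on a Calpain-1 Inhibitor

The source may hold more compounds than are shown below. What is called first, only, known or untested is meant among the compounds shown, and "the series" means these compounds.

Two measured compounds share one core and differ only in the halogen on the ring. Compound 1 `O=C(O)/C(S)=C/c1ccccc1Cl` in an assay on isolated protein for inhibition of Calpain-1 catalytic subunit (Sus scrofa) (a higher number here means a weaker inhibitor, a lower number a stronger inhibitor), gives 20700 nM. Compound 2 `O=C(O)/C(S)=C/c1ccc(I)cc1` in this assay gives 5200 nM, the lower of the two numbers, with compound 1 standing at a gap beyond the scatter. Compound 3 `O=C(O)/C(S)=C/c1ccc(Br)cc1` is not yet measured; it differs from compound 2 by bromo in place of iodo on an aromatic carbon. Among the compounds with values here, no measured pair shows such a swap, so the expected step of a 1.3-fold higher number from compound 2 to compound 3 (0.13 log units; within the scatter) is small, toward a slightly higher number, possibly within the scatter. Compound 3 is expected to give 7000 nM, within 3000 nM to 16000 nM.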

Compound 3, half-maximal inhibitory concentration: 1500 nM
Estimate against measurement, compound 3: 4.7-fold (0.67 log units) above; measured number outside the range, below it.
By their numbers in this assay, from the lowest: compound 3; then compound 2; then compound 1.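

Swapping iodo for bromo on this aromatic carbon gives a 3.5-fold lower number from compound 2 to compound 3 (0.54 log units; beyond the scatter) in this assay, so this position responds to a change of one halogen atom, even though the swap leaves the ring, the net charge and the hydrogen-bond donor and acceptor counts unchanged. Within the data shown here, this is the first change in a single place that can be read. Nothing measured here explains why bromo gives the lower number.

A single pair cannot show a trend across substituents. As far as these compounds go, how a fluoro or a methoxy group at this position would compare with bromo remains open.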